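This account rests on a few compounds, and the source may have more. Where it says the series, first, only, none or still open, it means among the compounds named here.

Compound 1, `CN(C)CCCCCSC1=Nc2ccccc2C(CC(=O)NCc2ccccc2)N1c1ccc(-c2ccc(F)cc2)cc1`, and compound 2, `CN(C)CCCCCSC1=Nc2ccccc2C(CC(=O)NCc2ccccc2)N1c1ccc(-c2ccccc2)cc1`, share one core and differ in a single place: hydrogen in place of fluoro on an aromatic carbon. In an assay on cells for inhibition of Voltage-dependent T-type calcium channel subunit alpha-1I (Homo sapiens), read by patch clamp, tested at 10 uM (a higher number here means more inhibition at the concentration tested (going by the name of the read-out), a lower number less inhibition), compound 1 gives 66.7%, while compound 2 gives 85.6%, so the change brings a number 18.9 percentage points higher from compound 1 to compound 2 (beyond the scatter).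

Compound 3, `O=C(CC1c2ccccc2N=C(SCCCCCN2CCCC2)N1c1ccc(-c2ccc(F)cc2)cc1)NCc1ccc(F)cc1`, is built on a different core; how that core differs from the core of compound 1 is not broken down here. In this assay compound 3 gives 35.1%, which is the lowest of the three measured numbers, and its gaps to compound 1 and compound 2 are both beyond the usual scatter.

Compound 4, `O=C(CC1c2ccccc2N=C(SCCCCCN2CCCC2)N1c1ccc(-c2ccc(F)cc2)cc1)NCc1ccccc1`, has not yet been measured. It differs from compound 3 by hydrogen in place of fluoro on an aromatic carbon. This is the same change as that from compound 1 to compound 2, made at a place described in the same words, on an aromatic carbon of a six-membered aromatic ring of carbon only, para to a large group; read one bond further out, however, it is 4-fluorobenzyl to benzyl here, where it was 4-fluorophenyl to phenyl before, so the surroundings are not identical.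

Going by the values given here, only the one earlier step is available, and it points upward, so from compound 3 to compound 4 a step of a number 12.9 percentage points higher from compound 3 to compound 4 (beyond the scatter) is expected, somewhat smaller than the earlier one since the change sits on a different part of the molecule. For compound 4 the expected value in this assay is 48%, likely between 28% and 68%.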

Compound 4, a percentage reported as inhibition, at one concentration (the size of the read-out at that concentration, not a potency): 68.2%
For compound 4 the middle estimate is 20.2 percentage points below the measured one; measured number above the stated range.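

In this assay, hydrogen in place of fluoro raises the number again, with a number 33.1 percentage points higher from compound 3 to compound 4 (beyond the scatter). The direction of the change therefore carries over from one core to the other, but its size does not: the same change on two cores in this assay, a number 18.9 percentage points higher (beyond the scatter) from compound 1 to compound 2 and a number 33.1 percentage points higher (beyond the scatter) from compound 3 to compound 4, 14.2 percentage points apart, beyond the scatter of two such steps

Going by these compounds alone, this rests on only two pairs, and the fluoro leaves a 4-fluorophenyl in one pair and a 4-fluorobenzyl in the other, so the difference in size cannot be assigned to the amine at the end of the chain alone, and the result is no general rule for the series; taken on its own, pyrrolidin-1-yl in place of dimethylamino gives a number 1.5 percentage points higher from compound 1 to compound 4 (within the scatter), a step that stays within the scatter.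

The compounds shown leave open whether the same swap keeps its direction with a piperidine or morpholine at the end of the chain, or with a shorter chain between the sulfur and the amine. They also leave open what chloro or methoxy would do where the fluoro stood, and whether replacing the fluoro that remains on the 4-fluorophenyl of compound 4 would add to the gain.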